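The compounds below may be only part of what the source reports. "The series", "measured", "known", "first", "only" and "open" are said of these compounds alone.

Working notes on the series. In an assay on 786-0 cells for inhibition of phosphatidylinositol 4,5-bisphosphate 3-kinase catalytic subunit beta isoform (Homo sapiens), with a stated time of 1 h (on this read-out higher numbers stand for weaker inhibition and lower numbers for stronger inhibition), compound 1 `C[C@H](Nc1ncnc2[nH]cnc12)c1cc2ccccn2c(=O)c1-c1ccccc1` gives "not determined" (no result reported) and compound 2 `Cc1ccc2cc([C@H](C)Nc3ncnc4[nH]cnc34)c(-c3ccccc3)c(=O)n2c1` gives "not determined" (no result reported), so neither carries a result there. For the measured compounds named here, compound 3 `C[C@H](Nc1ncnc2[nH]cnc12)c1cc2ccc(F)cn2c(=O)c1-c1ccccc1` is the only member with a number: in this assay compound 3 gives 191 nM, so it is the sole reference point for this step. Compound 4 `C[C@H](Nc1nc(N)nc(N)c1C#N)c1cc2ccc(F)cn2c(=O)c1-c1ccccc1` differs from compound 3 in one place: a group of 10 heavy atoms (5 carbon, 5 nitrogen; one six-membered aromatic ring with 2 hetero atoms) in place of a group of 9 heavy atoms (5 carbon, 4 nitrogen; one five-membered aromatic ring with 2 hetero atoms, one six-membered aromatic ring with 2 hetero atoms), on an amine nitrogen The new group keeps the amine attachment on the saturated chain carbon and adds a nitrile plus a second hydrogen-bond donor. Going by the values given here, no measured pair shows what such a swap does here, so the expectation rests on compound 3 alone. The step from compound 3 to compound 4 is expected to be modest, toward weaker inhibition, as a 1.7-fold higher number from compound 3 to compound 4 (0.22 log units; within the scatter), and not clearly beyond the scatter. Compound 4 is thus estimated at 320 nM, with a range from 80 nM to 1300 nM.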

Compound 4, half-maximal inhibitory concentration: 241 nM
Compound 4: the middle estimate sits 1.3-fold (0.12 log units) above what was measured; low and high end bracket the measured number.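

In this assay the change on the amine nitrogen gives a 1.3-fold higher number from compound 3 to compound 4 (0.10 log units; within the scatter) and so stays within the scatter. This position therefore accepts 2,6-diamino-5-cyanopyrimidin-4-yl, with one aromatic ring, in place of the two-ring group of compound 3 without a clear loss or gain. Nothing measured here explains this result.

Going by these compounds, it remains open which part of the new group matters to the read-out. A version with a chlorine or a methyl in place of the nitrile would test this.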